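The source may hold more compounds than are shown below. What is called first, only, known or untested is meant among the compounds shown, and "the series" means these compounds.

Working notes on the series. For the measured compounds named here, in a physicochemical assay for lipophilicity, using the shake flask method, in phosphate buffer, measured as octanol-water partition, with a stated time of 30 min, at pH 7.4 (a lower number here means a more polar compound, a higher number a more lipophilic compound), compound 1 `Fc1ccc2c(c1CNc1ncc(Oc3ccccc3)c3nncn13)CCO2` gives 3.5 and compound 2 `CN(C(=O)c1ccccc1)c1cnc(NCc2c(F)ccc3c2CCO3)n2cnnc12` gives 2.4, so compound 2 holds the lower of the two numbers so far. Going by the values given here, the one measured step is large and beyond the scatter: a number 1.10 log units lower from compound 1 to compound 2 (beyond the scatter), with benzoyl(methyl)amino in place of phenoxy on an aromatic carbon.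

Compound 3 `O=C(Nc1cnc(NCc2c(F)ccc3c2CCO3)n2cnnc12)c1cccnc1` has not yet been measured in this assay. Its change from compound 2 is ((pyridin-3-yl)carbonyl)amino in place of benzoyl(methyl)amino on an aromatic carbon. The group that entered in the measured step is the one that now leaves, so that step bears on this change only indirectly. Among the compounds with values here, no measured step shows a ring of carbon only exchanged for a ring with a hetero atom, and none shows the amide hydrogen appearing. A downward step smaller than a number 1.10 log units lower from compound 1 to compound 2 (beyond the scatter) is therefore expected, though with little support from the data. The expected step is a number 0.40 log units lower from compound 2 to compound 3 (beyond the scatter). The estimate for compound 3 is 2, with an expected range of 1.5 to 2.5.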

Compound 3, distribution coefficient: 2
Compound 3: the middle estimate sits on the measured number at the digits printed; low and high end bracket the measured number.
By their numbers in this assay, from the lowest: compound 3; then compound 2; then compound 1.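

In this assay the exchange of benzoyl(methyl)amino for ((pyridin-3-yl)carbonyl)amino on this aromatic carbon gives a number 0.40 log units lower from compound 2 to compound 3 (beyond the scatter) and shows that the number still moves when the group that entered in the earlier step is itself replaced. This single step combines two changes, since the six-membered aromatic ring of carbon only becomes a ring with a hetero atom and the amide hydrogen appears, so the size of the step belongs to the pair of changes and cannot be divided between them. Measured against the phenoxy group, ((pyridin-3-yl)carbonyl)amino gives a number 1.50 log units lower from compound 1 to compound 3 (beyond the scatter) and this is the widest gap in the series, with the three groups at this place now spanning a clear range on the shared core.

Open, on these data alone, is how much of the step goes with the ring nitrogen and how much with the amide hydrogen, which a benzoylamino group at this place would help to separate. Also open is where an amine or a carboxylic acid on this aromatic carbon would fall relative to these three groups, and no measured finding here gives a reason for any of these differences.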